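The source may hold more compounds than are shown below. What is called first, only, known or untested is meant among the compounds shown, and "the series" means these compounds.

Values in a functional assay on CCRF-CEM cells (Homo sapiens) for antiproliferative activity, read by cell counting, with a stated time of 96 h; on this read-out higher numbers stand for weaker inhibition and lower numbers for stronger inhibition:
- compound 1 `CC(Nc1ccccc1Oc1ccc(Cl)cc1)=C1C(=O)CC(c2ccccc2)CC1=O`: 190 nM
- compound 2 `CC(Nc1ccccc1Oc1ccccc1)=C1C(=O)CC(c2ccccc2)CC1=O`: 170 nM
- compound 3 `COc1cc(Oc2ccccc2NC(C)=C2C(=O)CC(c3ccccc3)CC2=O)ccc1N`: not yet measured

Within the data shown here, only two numbers exist so far, and compound 2, at 170 nM, stands level with compound 1 within the scatter. The next change goes from compound 2 to compound 3: 4-amino-3-methoxyphenyl in place of phenyl on an oxygen on an aromatic ring. Among the measured compounds shown here, one measured step bears on it, a 1.1-fold lower number from compound 1 to compound 2 (0.05 log units; within the scatter), which also falls on this phenyl. As far as these compounds go, that step covers a single chloro, and the series holds no measured amino or methoxy example, so the direction in this assay remains open and the range must stay wide. The expectation rests on compound 1 and compound 2 showing no step beyond the scatter. The estimate is a 1.2-fold higher number from compound 2 to compound 3 (0.07 log units; within the scatter). Compound 3 is expected at about 200 nM, with an estimated range of 70 nM to 600 nM.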

Compound 3, half-maximal inhibitory concentration: 12 nM
Compound 3: the middle estimate sits 17-fold (1.22 log units) above what was measured; measured number outside the range, below it.
By their numbers in this assay, from the lowest: compound 3; then compounds 2 and 1 (each within the scatter of the next).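

In this assay, the group on the oxygen on an aromatic ring proves able to move the number by much more than the chloro-to-hydrogen pair suggested: 4-amino-3-methoxyphenyl in place of phenyl gives a large step (a 14-fold lower number from compound 2 to compound 3 (1.15 log units; beyond the scatter)), and in place of 4-chlorophenyl it gives another (a 16-fold lower number from compound 1 to compound 3 (1.20 log units; beyond the scatter)). Both steps lie beyond the scatter and start from two compounds that stand level within it, so the result holds whichever of the two serves as the reference. No measurement on hand accounts for the size of these steps.

Amino and methoxy enter together here, so whether either group alone carries the step remains open. Also open, as far as these compounds go, is how the series reads with an acetamide or a dimethylamino group in place of the amino group.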